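This account rests on a few compounds, and the source may have more. Where it says the series, first, only, none or still open, it means among the compounds named here.

Measured compounds:

Compound 1 `Cc1cc(C)cc(NC(=O)COc2cc(C)nc3ccc(OC(F)(F)F)cc23)c1` — in a toxicity assay on HepG2 cells (Homo sapiens) for inhibition, read by CellTiter-Glo, with a stated time of 48 h (on this read-out lower numbers stand for stronger inhibition and higher numbers for weaker inhibition), compound 1 gives > 100000 nM, which is a limit of the assay and not a number.
Compound 2 `COc1ccc2nc(C)cc(OCC(=O)NCc3cc(C)cc(C)c3)c2c1` — in this assay compound 2 gives > 100000 nM, again a limit and not a number.
Compound 3 `COc1ccc2nc(C)cc(OCC(=O)Nc3ccc(Cl)c(C(F)(F)F)c3)c2c1` — in this assay compound 3 gives 79400 nM.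

Compound 2 therefore stands at the limit of > 100000 nM in this assay, at which 2 of the 3 values shown sit, so its standing is known only as a bound, not as a position within a range. Of the three values, only compound 3 carries a number, and that number sits close to the same limit. For the measured compounds named here, no pair of measured compounds differs in a single place, so no measured step is available to calibrate the change under study.

Compound 4 `COc1ccc2nc(C)cc(OCC(=O)Nc3ccncn3)c2c1` is the next compound in the series, differing from compound 2 by pyrimidin-4-yl in place of 3,5-dimethylbenzyl on an amide-type nitrogen.

With compound 2 at a limit and compound 3 near it, the step from compound 2 to compound 4 is expected to be a step that the limit leaves unreadable from compound 2 to compound 4, that is, no movement beyond the usual scatter, and the most likely outcome is again a limit rather than a number. Compound 4 is estimated at 120000 nM, with a range from 50000 nM to 300000 nM.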

Compound 4, half-maximal inhibitory concentration: > 100000 nM
Compound 4 ended at the assay's limit; the forecaster's own chance of this, stated with the estimate: 70%; the middle value does not contradict the limit.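

No size can be read for the change from compound 2 to compound 4 in this assay, as both values are limits and not numbers: the limit of > 100000 nM in this assay, at which 3 of the 4 values shown sit.

Still open is whether pyrimidin-4-yl in place of 3,5-dimethylbenzyl on an amide-type nitrogen changes this read-out at all, as the compounds shown hold no numerical value for such a comparison.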